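Methyl in Place of Methoxy: Expectation for Compound 3

A few compounds are considered here, and "the series" means these few. Any claim that something is new, unique, unknown or untested is made for them only; others in the source may bear on it.

Compound 1, `COc1cc(Cl)nc2n/c(=N/C(=O)c3c(-c4ccc(Cl)cc4Cl)noc3C)sn12`: 40.8%
Compound 2, `COc1cc(Cl)nc(NC(=S)NC(=O)c2c(-c3ccc(Cl)cc3Cl)noc2C)n1`: 56.3%

Both numbers come from a functional assay on the whole organism (strain L.) for inhibition, with Echinochloa crus-galli as the target, with a stated time of 72 h, tested at 100 mg/L; a lower number here means less inhibition of growth, a higher number more inhibition of growth at the concentration tested. Among the measured compounds shown here, compound 1 gives the lower of the two readings; compound 2 lies higher by a margin beyond the usual scatter, but no step between this pair has been traced, so only the two readings themselves can be stated. Compound 3, `Cc1onc(-c2ccc(Cl)cc2Cl)c1C(=O)/N=c1/nc2nc(Cl)cc(C)n2s1`, has not yet been measured. It differs from compound 1 in one place: methyl in place of methoxy on an aromatic carbon. For the measured compounds named here, no measured pair shows what this change does, so the expected step is small, a number 1.2 percentage points higher from compound 1 to compound 3 (within the scatter), with no clear direction. Compound 3 is estimated at 42%, within a range from 22% to 62%.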

Compound 3, percent growth inhibition at one concentration: 55.6%
For compound 3 the middle estimate is 13.6 percentage points below the measured one; the measured number falls inside the stated range.
By their numbers in this assay, from the lowest: compound 1; then compounds 3 and 2 (each within the scatter of the next).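

In this assay, among the compounds shown here, putting methyl in place of methoxy on this aromatic carbon gives a number 14.8 percentage points higher from compound 1 to compound 3 (beyond the scatter) and so shows that this position of the shared core can change growth inhibition, which the earlier compounds could not show. This is a single pair, so it gives the size of one change and no trend. Nothing available explains the rise. Going by these compounds, whether it reflects the gain of methyl or the loss of methoxy remains open, as does how an amine, an ethyl group or a plain hydrogen would read on this carbon.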